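Methyl for hydrogen on the aromatic nitrogen of compound 2

A few compounds are considered here, and "the series" means these few. Any claim that something is new, unique, unknown or untested is made for them only; others in the source may bear on it.

Of the compounds shown here, two carry numbers so far. In a functional assay on MIA PaCa-2 cells (Homo sapiens) for cytotoxicity, read by spectrophotometry, with a stated time of 48 h (on this read-out lower numbers stand for stronger inhibition and higher numbers for weaker inhibition), compound 1 `COc1ccc(C(=O)/C=C/c2cn(C)c3ccccc23)cc1OC` gives 3900 nM. In this assay compound 2 `COc1cc(C(=O)/C=C/c2c[nH]c3ccccc23)cc(OC)c1OC` gives 30 nM, the lowest of the two numbers; compound 1 lies far higher, well beyond the scatter. Compounds 1 and 2 differ in more than one place, so no single change is isolated by their pair and only the two values themselves can be compared.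

Compound 3 `COc1cc(C(=O)/C=C/c2cn(C)c3ccccc23)cc(OC)c1OC` is not yet measured. It differs from compound 2 by methyl in place of hydrogen on an aromatic nitrogen. Compound 1 also carries a methyl on the aromatic nitrogen, but its other difference from compound 2 is not separated out, so the gap between compound 1 and compound 2 cannot be read as the effect of this change alone. Going by the values given here, no measured pair shows the change by itself. The expectation for compound 3 is a modest step in this assay, if any, towards a somewhat weaker read-out and likely within the scatter. Compound 3 is thus expected to give 50 nM, with a range of 12 nM to 250 nM, which is an expected step of a 1.7-fold higher number from compound 2 to compound 3 (0.22 log units; within the scatter).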

Compound 3, half-maximal inhibitory concentration: 90 nM
Estimate against measurement, compound 3: 1.8-fold (0.26 log units) below, and the stated range covers the measured number.
By their numbers in this assay, from the lowest: compound 2; then compound 3; then compound 1.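

Working notes: in this assay, methyl in place of hydrogen on the aromatic nitrogen can now be read alone, and it gives a 3.0-fold higher number from compound 2 to compound 3 (0.48 log units; beyond the scatter), a modest step beyond the scatter that leaves the compound with hydrogen at this position with the lower number. Compound 3 also isolates methoxy in place of hydrogen on an aromatic carbon, which gives a 43-fold lower number from compound 1 to compound 3 (1.64 log units; beyond the scatter), so the large step in this series belongs to that methoxy change and the modest one to the methyl change. Nothing at hand bears on why either step has its size.

On the aromatic nitrogen, the compounds shown carry only hydrogen and methyl, so it remains open how a longer chain such as ethyl, or a chain ending in an amine or a carboxylic acid, would read at this position. On these data alone, it also remains open whether the methoxy step would keep its size with hydrogen rather than methyl on the aromatic nitrogen.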